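The source may hold more compounds than are shown below. What is called first, only, known or untested is meant among the compounds shown, and "the series" means these compounds.

In a functional assay on RS4-11 cells (Homo sapiens) for inhibition, read by CCK-8 assay, with a stated time of 48 h (a lower number here means a stronger inhibitor, a higher number a weaker inhibitor), compound 1 `O=S(=O)(NCCNC(=S)Nc1cccc(Cl)c1)c1ccc(-c2ccccc2OCc2ccccc2)s1` reads > 50000 nM, which is a limit of the assay and not a number. Compound 3 `O=C(NCCNS(=O)(=O)c1ccc(-c2ccccc2OCc2ccccc2)s1)Nc1cccc([N+](=O)[O-])c1` keeps the core of compound 1 and changes it in one place, on an amine nitrogen: a group of 12 heavy atoms (7 carbon, 2 nitrogen, 3 oxygen; one six-membered aromatic ring of carbon only) in place of a group of 10 heavy atoms (7 carbon, 1 nitrogen, 1 sulfur, 1 chlorine; one six-membered aromatic ring of carbon only), on an amine nitrogen. The group that enters there is (3-nitrophenyl)carbamoyl. Compound 2 `O=C(NCCNS(=O)(=O)c1ccc(-c2ccccc2Oc2ccc(O)c(O)c2)s1)Nc1cc(Cl)cc(Cl)c1` also carries a carbamoyl group on that amine nitrogen and gives 4500 nM in this assay, though the rest of compound 2 differs from compound 1 as well. On that single comparison, a gain in this assay is expected, with the estimated step of an at least 2.5-fold lower number from compound 1 to compound 3 (0.39 log units; beyond the scatter) running toward a lower number, a stronger inhibitor. Its size remains uncertain, and a reading at the limit again is possible. Compound 3 is estimated at 20000 nM, with an expected range from 6000 nM to 50000 nM.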

Compound 3, half-maximal inhibitory concentration: > 20000 nM
Compound 3: no number, only a limit (the forecaster's own chance of this, stated with the estimate: 35%); the middle value lies on the limit itself.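

Going by these compounds alone, compound 1 and compound 3 both read as limits and not as numbers in this assay, so no step between them can be read. The compounds shown leave open whether placing (3-nitrophenyl)carbamoyl on that amine nitrogen changes inhibition at all, and in which direction.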